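Methoxy on the second arylidene of a nitro dienone

The source may hold more compounds than are shown below. What is called first, only, known or untested is meant among the compounds shown, and "the series" means these compounds.

Compound 1 `O=C1/C(=C/c2ccccc2)CCC/C1=C\c1cccc([N+](=O)[O-])c1`: 1700 nM
Compound 2 `O=C1/C(=C/c2ccccc2)CCC/C1=C\c1ccc([N+](=O)[O-])cc1`: 8350 nM
Compound 3 `COc1ccc(/C=C2\CCC/C(=C\c3cccc([N+](=O)[O-])c3)C2=O)cc1`: 7980 nM

All three were measured in a functional assay on MOLT-4 cells (Homo sapiens) for cytotoxicity, with a stated time of 72 h; a lower number here means a stronger inhibitor, a higher number a weaker inhibitor. Compound 1 and compound 2 have the same atoms joined differently; the difference between the two cores is not broken down here. Compound 2 gives the highest of the three numbers, though its value and that of compound 3 lie within the scatter of each other, while compound 1 sits well apart from both.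

Compound 3 is compound 1 with methoxy in place of hydrogen on an aromatic carbon, and that change gave a 4.7-fold higher number from compound 1 to compound 3 (0.67 log units; beyond the scatter). Compound 4 `COc1ccc(/C=C2\CCC/C(=C\c3ccc([N+](=O)[O-])cc3)C2=O)cc1`, not yet measured in this assay, bears the same change made on compound 2: methoxy in place of hydrogen on an aromatic carbon. The place of the change is described in the same words for both pairs, so this is the same change, seen a second time.

On that basis the step from compound 2 to compound 4 is expected to be a 3.6-fold higher number from compound 2 to compound 4 (0.56 log units; beyond the scatter), resting on the earlier step of a 4.7-fold higher number from compound 1 to compound 3 (0.67 log units; beyond the scatter). Compound 4 is therefore estimated at 30000 nM, within a range from 10000 nM to 90000 nM.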

Compound 4, half-maximal inhibitory concentration: 300000 nM
Beside the measured number, compound 4's estimate is 10-fold (1.00 log units) below it; the measured number lies above the stated range.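

On the core of compound 2, the change from phenyl to 4-methoxyphenyl gave a 36-fold higher number from compound 2 to compound 4 (1.56 log units; beyond the scatter) in this assay. Both steps run the same way, so across these two pairs the direction of the change carried from one core to the other, but its size did not: the same change on two cores in this assay, a 4.7-fold higher number (0.67 log units; beyond the scatter) from compound 1 to compound 3 and a 36-fold higher number (1.56 log units; beyond the scatter) from compound 2 to compound 4, 7.7-fold (0.88 log units) apart, beyond the scatter of two such steps

This shows that, in this series, the size of the step measured on one core cannot simply be transferred to the other, but two pairs give no general rule for further cores and do not show what in the cores sets the gap between the steps.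

The compounds shown have only methoxy as the added group, so it remains open whether a hydroxy, chloro or dimethylamino group in the same place would also show a step that differs between the two cores. As far as these compounds go, whether the same holds for a core carrying an amine or a carboxylic acid in place of the nitro group also remains open.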